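Swapping fluoro for bromo on compound 2

A few compounds are considered here, and "the series" means these few. Any claim that something is new, unique, unknown or untested is made for them only; others in the source may bear on it.

Going by the values given here, in a functional assay on P388 cells (Mus musculus) for inhibition (a lower number here means a stronger inhibitor, a higher number a weaker inhibitor), compound 2 `O=C1/C(=C/c2ccc(F)cc2)CCc2ccccc21` gives 15900 nM, the only actual number so far. Compound 1 `COc1cccc(/C=C2\Cc3ccccc3C2=O)c1` reads > 50000 nM, which is a limit of this assay and not a number. Compound 3 `O=C1/C(=C/c2ccc(Br)cc2)CCc2ccccc21` has not been measured yet. It keeps the shared core of compound 2 and carries bromo in place of fluoro on an aromatic carbon, para to a large group: bromo in place of fluoro on an aromatic carbon. Among the compounds with values here, no measured pair of compounds shows what a change like this does, so any forecast is uncertain. One atom is exchanged, and no ring, charge or hydrogen-bond donor or acceptor changes. The expected step of a 1.3-fold lower number from compound 2 to compound 3 (0.12 log units; within the scatter) therefore stays within the usual scatter, with no clear direction. Compound 3 is estimated at 12000 nM, with an expected range of 4000 nM to 36000 nM.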

Compound 3, half-maximal inhibitory concentration: 20400 nM
For compound 3 the middle estimate is 1.7-fold (0.23 log units) below the measured one; the range from low to high includes it.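

In this assay, going by these compounds alone, this is the first pair of compounds that differ in one place, and exchanging fluoro for bromo gives a 1.3-fold higher number from compound 2 to compound 3 (0.11 log units; within the scatter). At this aromatic carbon, para to a large group, the two compounds therefore cannot be told apart, so this assay does not distinguish fluoro from bromo here. This single pair speaks only for these two groups at this one place and sets no wider pattern.

From the compounds shown here alone, whether a different kind of group here, such as an amine or a carboxylic acid, would shift the number beyond the usual scatter remains open. Compound 1 cannot help answer this, since its reading is a limit of the assay and not a number: the limit of > 50000 nM in this assay, at which 1 of the 3 values shown sits.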